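This account rests on a few compounds, and the source may have more. Where it says the series, first, only, none or still open, it means among the compounds named here.

Of the compounds shown here, three built on one shared core have been measured in an assay on HEK293 cells for displacement of a labelled ligand from growth hormone secretagogue receptor type 1 (Homo sapiens), with a stated time of 60 min; on this read-out higher numbers stand for weaker inhibition and lower numbers for stronger inhibition. Compound 1 `Cc1ncccc1-c1nc2cn(-c3cccc(OC(C)C)c3)nc2c(=O)n1C[C@H]1CCCN(C[C@H]2CCCO2)C1` gives 11 nM in this assay, and compound 3 `Cc1ccccc1-c1nc2cn(-c3ccc(Cl)cc3)nc2c(=O)n1CC1CCCN(C(C)C)C1` gives 0.28 nM. Compound 2 `COc1cccc(-n2cc3nc(-c4cccnc4C)n(C[C@H]4CCCN(CC5CCOC5)C4)c(=O)c3n2)c1` gives 60 nM, which is the highest of the three numbers and therefore marks compound 2 as the weakest binder of this set; its gap to compound 1 and its much larger gap to compound 3 both lie beyond the scatter of repeated measurements. Among the measured compounds shown here, compound 2 and compound 1 differ in more than one place, so their two values show only that compound 1 binds more strongly.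

Compound 4 `CCO[C@H](C)CN1CCC[C@H](Cn2c(-c3cccnc3C)nc3cn(-c4cccc(OC)c4)nc3c2=O)C1` has not yet been measured. It differs from compound 2 in a single place: 1-ethoxyethyl in place of oxolan-3-yl on a saturated chain carbon bound to an amine nitrogen in a ring. The group that leaves and the group that enters are counted alike in heavy atoms and in hydrogen-bond acceptors, the one being a ring and the other an open chain. For the measured compounds named here, no measured pair of compounds shows this exact change, so the expectation rests on compound 2 alone. The step from compound 2 to compound 4 in this assay is expected to be small, most likely within the scatter, with a slight lean toward a lower number, as a 1.5-fold lower number from compound 2 to compound 4 (0.18 log units; within the scatter). For compound 4 the estimate in this assay is 40 nM, with a range from 15 nM to 150 nM.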

Compound 4, half-maximal inhibitory concentration: 40 nM
Compound 4: the middle estimate sits on the measured number at the digits printed; the measured number falls inside the stated range.
By their numbers in this assay, from the lowest: compound 3; then compound 1; then compounds 4 and 2 (each within the scatter of the next).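

In this assay, among the compounds shown here, putting 1-ethoxyethyl in place of oxolan-3-yl on a saturated chain carbon bound to an amine nitrogen in a ring gives a 1.5-fold lower number from compound 2 to compound 4 (0.18 log units; within the scatter), the first step in this set that can be read at a single place. Within the scatter, this read-out does not separate the closed ring from the open chain, two groups with the same counts of heavy atoms and hydrogen-bond acceptors, so for this pair the ring is not required to keep binding at this level. Nothing measured here explains why the two groups score alike.

This single pair cannot show whether the same holds for groups of a different kind at this place, such as a carboxylic acid, a primary amine or a longer ether chain. It also leaves open whether the defined stereocentre of 1-ethoxyethyl matters, since only one arrangement at that centre is shown, and whether the same swap would give a similarly small step with the other substituents seen on compound 1 or compound 3.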